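Notes on the aryl urea series: heptyl replaced by bromo

The source may report more compounds than this note shows. Statements on the series, on what has been measured and on what is new or still open speak of the compounds shown alone.

Of the compounds shown here, three of the shared core have been measured: compound 1 is `CCCCCCc1ccc(NC(=O)N[C@H](C)c2ccccc2)cc1`, compound 2 is `CCCCCCCc1ccc(NC(=O)N[C@H](C)c2ccccc2)cc1` and compound 3 is `CCCCCCCc1ccc(NC(=O)N[C@@H](C)c2ccccc2)cc1`. In an ADME assay on the whole organism with Oryza sativa as the target, tested at 0.1 uM (a lower number here means a stronger effect, a higher number a weaker effect of the compound at the concentration tested), compound 1 gives 100%, compound 2 gives 100% and compound 3 gives 100%. Compound 2 thus stands level with both neighbours at the digits shown.

Two steps have been measured. Among the measured compounds shown here, the first is no change at the digits printed from compound 1 to compound 2 (within the scatter), methyl in place of hydrogen on a saturated chain carbon, six bonds along the chain from an aromatic carbon. The second is no change at the digits printed from compound 2 to compound 3 (within the scatter), which rests only on (the fact that compounds 2 and 3 differ only in the configuration as drawn). Both steps sit inside the scatter.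

Compound 4, `C[C@@H](NC(=O)Nc1ccc(Br)cc1)c1ccccc1`, has not yet been measured. The change from compound 2 is bromo in place of heptyl on an aromatic carbon. Neither measured step touches the aromatic carbon; both altered the chain or its configuration and moved nothing. The present change removes the heptyl entirely, which is larger than either measured step, so the expected range is widened on the low side while the centre stays near the measured plateau. Compound 4 is expected at 95%, with a range from 70% to 100%. The expected step of a number 5 percentage points lower from compound 2 to compound 4 (within the scatter) is estimated to be none beyond the scatter.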

Compound 4, a percentage reported as activity, at one concentration (the size of the read-out at that concentration, not a potency): 100%
Beside the measured number, compound 4's estimate is 5 percentage points below it; low and high end bracket the measured number.
By their numbers in this assay, from the lowest: compounds 1, 2, 3 and 4 (each within the scatter of the next).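

Working notes on the aromatic carbon: this is the first measured change at this place, and it removes the whole heptyl, 7 heavy atoms, in favour of the single bromine atom. In this assay that exchange gives no change at the digits printed from compound 2 to compound 4 (within the scatter) and the matching exchange of hexyl for bromo gives no change at the digits printed from compound 1 to compound 4 (within the scatter) so in these two pairs the read-out does not register the presence of the alkyl chain at this place, just as it did not register the earlier change in chain length. Nothing measured here speaks to why the read-out stays level across this exchange.

Still open, going by these compounds, is whether an amine or a carboxylic acid on this aromatic carbon, or a chain longer than heptyl, would separate from these four compounds in this assay at the concentration tested. With all four level, the compounds shown offer no example of a change that moves this read-out, so they do not tell whether this place or the rest of the shared core has any bearing on it.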